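The source may report more compounds than this note shows. Statements on the series, on what has been measured and on what is new or still open speak of the compounds shown alone.

In a functional assay on L1210 cells (Mus musculus) for inhibition, read by cell counting, with a stated time of 2 days (on this read-out lower numbers stand for stronger inhibition and higher numbers for weaker inhibition), compound 2 `C=C(Br)C(=O)Nc1cccc(-c2cn3nc(-c4ccc(F)cc4)sc3n2)c1` gives 250 nM, the lowest of the two numbers shown. Compound 1 `CCc1ccc(-c2nn3cc(-c4cccc(N)c4)nc3s2)cc1` gives 6000 nM, and the gap between them is beyond the usual scatter. Compound 3 `COc1cccc(-c2nn3cc(-c4cccc(N)c4)nc3s2)c1` gives > 250000 nM, which is a limit of the assay and not a number. That is the limit of > 250000 nM in this assay, at which 1 of the 3 values shown sits. Compound 4 `C=C(Br)C(=O)Nc1cccc(-c2cn3nc(-c4ccc(Cl)cc4)sc3n2)c1` has not yet been measured in this assay. It differs from compound 2 in one place (chloro in place of fluoro on an aromatic carbon). No measured pair among these compounds carries this change, so the expectation rests on the change alone. The step of a 1.3-fold lower number from compound 2 to compound 4 (0.10 log units; within the scatter) is expected to stay within the usual scatter, with no direction claimed. Compound 4 is estimated at 200 nM, within a range from 80 nM to 600 nM.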

Compound 4, half-maximal inhibitory concentration: 1400 nM
Compound 4: middle estimate off by 7.0-fold (0.85 log units), on the low side; measured number above the stated range.
By their numbers in this assay, from the lowest: compound 2; then compound 4; then compound 1. At a limit, above all of these: compound 3.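

In this assay, chloro in place of fluoro gives a 5.6-fold higher number from compound 2 to compound 4 (0.75 log units; beyond the scatter) and so is not an interchangeable swap. Among these compounds, this shows that a single-atom change at this position, para to a large group, can shift the read-out, which the earlier compounds could not show, as no two of them differed in one place only. None of the evidence available bears on why this step occurs.

As far as these compounds go, what a hydrogen, a methyl group, a nitrile or an amine would give at this position stays open. So does whether the step would recur on other compounds.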